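Vero cytotoxicity notes: chalcone amide series, compounds 1 to 4

The source may hold more compounds than are shown below. What is called first, only, known or untested is meant among the compounds shown, and "the series" means these compounds.

compound 1 `COC(=O)c1cc(-c2cccc(NC(=O)c3ccc(/C=C/C(=O)c4cc(OC)c(OC)c(OC)c4)cc3)c2)on1` — > 50 ug/mL
compound 2 `COC(=O)c1cc(-c2cccc(NC(=O)c3ccc(/C=C/C(=O)c4ccccc4O)cc3)c2)on1` — "not determined" (no result reported)
compound 3 `COC(=O)c1cc(-c2cccc(NC(=O)c3ccc(/C=C/C(=O)c4ccc(OC)c([N+](=O)[O-])c4)cc3)c2)on1` — > 40 ug/mL

In an ADME assay on Vero cells (Chlorocebus sabaeus) for cytotoxicity, read by MTT assay, with a stated time of 72 h (a higher number here means that more compound is tolerated, a lower number that less compound is tolerated), compound 1 reaches only a limit, > 50 ug/mL. For compound 2 the read-out is "not determined" (no result reported). Compound 3 likewise stops at a limit, > 40 ug/mL. The step that the two limits leave unreadable from compound 1 to compound 3 is therefore not readable, since both of its ends are limits (the limit of > 50 ug/mL in this assay, at which 1 of the 3 values shown sits, (the limit of > 40 ug/mL in this assay, at which 1 of the 3 values shown sits)). Compound 3 thus stands within a set that holds no single number at all: two limits and one missing entry.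

Compound 4 `COC(=O)c1cc(-c2cccc(NC(=O)c3ccc(/C=C/C(=O)c4ccc(Cl)cc4Cl)cc3)c2)on1` differs from compound 3 by 2,4-dichlorophenyl in place of 4-methoxy-3-nitrophenyl on a carbonyl carbon. Among the compounds with values here, no measured step bears on this change; the only step on record, a step that the two limits leave unreadable from compound 1 to compound 3, is unreadable and concerns other groups. With both measured values sitting at limits, compound 4 is expected to be tolerated to a similar degree, estimated at 45 ug/mL with a range from 15 ug/mL to 120 ug/mL. The expected step is a step that the limit leaves unreadable from compound 3 to compound 4, which amounts to no change beyond the scatter, though a reported number rather than a limit is possible.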

Compound 4, half-maximal cytotoxic concentration: > 40 ug/mL
Compound 4 was reported as a limit; the forecaster's own chance of this, stated with the estimate: 55%; the middle value is on the limit's open side.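

Compound 4 also stops at a limit, > 40 ug/mL, like compound 1 and compound 3, so neither new step, from compound 3 or compound 1 to compound 4, can be read. The compounds shown leave open whether the group on the carbonyl carbon changes tolerance at all in this assay.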